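Halogen swap on the benzothiazole amine of a flavone

This account rests on a few compounds, and the source may have more. Where it says the series, first, only, none or still open, it means among the compounds named here.

Compound 2 `O=c1cc(-c2ccccc2)oc2cc(OCCCCNc3nc4ccc(Br)cc4s3)cc(O)c12` and compound 1 `O=c1cc(-c2ccccc2)oc2cc(OCCCCNc3nc4ccc(Cl)cc4s3)cc(O)c12` share one core and differ only in the halogen on the fused ring. In a functional assay on HeLa cells (Homo sapiens) for cytotoxicity, read by sulforhodamine B assay, with a stated time of 48 h (on this read-out lower numbers stand for stronger inhibition and higher numbers for weaker inhibition), compound 2 gives 6.56 ug/mL, the higher of the two numbers, while compound 1 gives 5.95 ug/mL; the step of a 1.1-fold higher number from compound 1 to compound 2 (0.04 log units; within the scatter) is within the scatter, so the two cannot be told apart. Compound 3 `O=c1cc(-c2ccccc2)oc2cc(OCCCCNc3nc4ccc(F)cc4s3)cc(O)c12` is the next member and has not been measured; it differs from compound 2 by fluoro in place of bromo on an aromatic carbon. Within the data shown here, the only measured step that bears on this change, the chloro-to-bromo step, was flat, so an exchange among halogens at this carbon is expected to shift this assay little if at all. For compound 3 the expected step is a 1.0-fold lower number from compound 2 to compound 3 (0.00 log units; within the scatter), and the estimated value is 6.5 ug/mL with a range from 3.2 ug/mL to 13 ug/mL.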

Compound 3, half-maximal inhibitory concentration: 5.03 ug/mL
For compound 3 the middle estimate is 1.3-fold (0.11 log units) above the measured one, and the stated range covers the measured number.
By their numbers in this assay, from the lowest: compounds 3, 1 and 2 (each within the scatter of the next).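

With fluoro at this carbon, all three halogens can now be compared in this assay, and both new steps stay within the scatter: a 1.3-fold lower number from compound 2 to compound 3 (0.12 log units; within the scatter) and a 1.2-fold lower number from compound 1 to compound 3 (0.07 log units; within the scatter). The flat result therefore no longer rests on the chloro-to-bromo step alone, and in these three compounds, the choice among fluoro, chloro and bromo on this aromatic carbon does not separate the values. Nothing available here offers an explanation for this flat result.

The compounds shown contain only halogens at this carbon, so they leave open whether a different kind of group, such as an amine or a carboxylic acid, would move the number beyond the scatter. They also leave open what a longer chain linking the two ring systems would do.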